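A Carboxyphenyl in Place of a Chlorophenyl

The source may hold more compounds than are shown below. What is called first, only, known or untested is meant among the compounds shown, and "the series" means these compounds.

Measured so far:
compound 1, `CCCCCCCCc1ccc(OCC(=O)Cn2nnc(SC)n2)cc1`: < 5%
compound 2, `CCCCCCCCc1ccc(OCC(=O)Cn2nnnc2-c2ccccc2Cl)cc1`: 42%

Both compounds were tested in an ADME assay on S9 fraction from liver (Rattus norvegicus) for metabolic stability, read by LC-MS, using NADPH, with a stated time of 30 min; a higher number here means that more of the compound is left, a lower number that less of the compound is left. For compound 1 the result < 5% is a limit of the assay and not a number, as stated in the limit of < 5% in this assay, at which 1 of the 2 values shown sits. Among the compounds with values here, compound 2 gives 42% in this assay, and it is the only real number among the two values shown.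

Compound 3, `CCCCCCCCc1ccc(OCC(=O)Cn2nnnc2-c2cccc(C(=O)O)c2)cc1`, has not yet been measured. It differs from compound 2 in one place: 3-carboxyphenyl in place of 2-chlorophenyl on an aromatic carbon. Within the data shown here, no step between two measured compounds is available for comparison, so the size of this change has no precedent here. Compound 3 is expected to give 55% in this assay, with a range from 30% to 85%. The step of a number 13 percentage points higher from compound 2 to compound 3 (beyond the scatter) is expected to be a small rise, possibly no larger than the usual scatter.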

Compound 3, percent of the compound remaining: < 5%
Compound 3: only a limit was reported (the forecaster's own chance of this, stated with the estimate: 5%); at least 50 percentage points between middle value and limit.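

In this assay, 3-carboxyphenyl in place of 2-chlorophenyl gives a number at least 37 percentage points lower from compound 2 to compound 3 (beyond the scatter). For compound 3 the value < 5% is a limit of the assay and not a number. This shows that the group on this aromatic carbon, with the rest of the molecule unchanged, can alone decide whether a measurable amount of compound is left, and the results now gather at the bottom of the range: the limit of < 5% in this assay, at which 2 of the 3 values shown sit.

The compounds shown leave open whether the drop follows from the carboxylic acid itself, from the loss of the chlorine, or from the different place of the group on the phenyl ring. A plain phenyl ring or a methyl ester at this position would tell these apart.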